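Furan to thiophene on the methoxy series: compound 4 forecast

A few compounds are considered here, and "the series" means these few. Any claim that something is new, unique, unknown or untested is made for them only; others in the source may bear on it.

Compound 1 `O=c1[nH]cnc2c1c(-c1ccoc1)cn2[C@@H]1O[C@H](CO)[C@@H](O)[C@H]1O` and compound 2 `COc1ncnc2c1c(-c1ccoc1)cn2[C@@H]1O[C@H](CO)[C@@H](O)[C@H]1O` share a ribose-bearing bicyclic core with furan-3-yl on it; the difference between the two cores is not broken down here. In a functional assay on HCT-116 cells (Homo sapiens), read by MTT assay, with a stated time of 72 h (a lower number here means a stronger inhibitor, a higher number a weaker inhibitor), compound 1 gives 14800 nM. In this assay compound 2 gives 130 nM, the lowest of the two numbers measured, and the gap to compound 1 lies beyond the scatter.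

Compound 3 `O=c1[nH]cnc2c1c(-c1cccs1)cn2[C@@H]1O[C@H](CO)[C@@H](O)[C@H]1O` differs from compound 1 by thiophen-2-yl in place of furan-3-yl on an aromatic carbon. In this assay compound 3 reports only a limit, > 20000 nM. The measured step is therefore a floor: an at least 1.3-fold higher number from compound 1 to compound 3 (0.13 log units; that floor lies within the scatter). Its size is bounded only because of the limit of > 20000 nM in this assay, at which 1 of the 3 values shown sits, so the true loss on moving to thiophen-2-yl in the compound 1 core may be larger than the floor shows.

Compound 4 `COc1ncnc2c1c(-c1cccs1)cn2[C@@H]1O[C@H](CO)[C@@H](O)[C@H]1O` is not yet measured. It differs from compound 2 by thiophen-2-yl in place of furan-3-yl on an aromatic carbon; the place described for both changes is the same word for word, so this is the same change made on the compound 2 core. The expected step from compound 2 to compound 4 is a 3.5-fold higher number from compound 2 to compound 4 (0.54 log units; beyond the scatter), set beside the measured floor an at least 1.3-fold higher number from compound 1 to compound 3 (0.13 log units; that floor lies within the scatter) and widened because the step in compound 1 to compound 3 rests on a limit, (the limit of > 20000 nM in this assay, at which 1 of the 3 values shown sits). Compound 4 is thus estimated at 450 nM in this assay, with a likely range from 130 nM to 2000 nM.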

Compound 4, half-maximal inhibitory concentration: 440 nM
Compound 4: middle estimate off by 1.0-fold (0.01 log units), on the high side; the range from low to high includes it.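

Carried onto the core of compound 2, thiophen-2-yl in place of furan-3-yl gives a 3.4-fold higher number from compound 2 to compound 4 (0.53 log units; beyond the scatter) in this assay, so the loss seen there can be read as a full step and not only as a floor. Set beside the same change on the core of compound 1, the comparison stays unresolved: the same change on two cores in this assay, an at least 1.3-fold higher number (0.13 log units; that floor lies within the scatter) from compound 1 to compound 3 and a 3.4-fold higher number (0.53 log units; beyond the scatter) from compound 2 to compound 4; the limit leaves it open whether they differ

Among the compounds shown here, compound 3 gives > 20000 nM, which is a limit and not a number, so the pair shows only that the step on the core of compound 2 does not conflict with the floor, not that the change costs the same on both cores.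

The two groups differ both in the hetero atom and in the point of attachment, and the compounds shown leave open which of these carries the step on the core of compound 2. Thiophen-3-yl or furan-2-yl at this place would separate the two, while a phenyl ring or an amine there would show whether the step extends beyond five-membered aromatic rings with 1 hetero atom.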